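Swapping Chloro for Fluoro in Compound 1

A few compounds are considered here, and "the series" means these few. Any claim that something is new, unique, unknown or untested is made for them only; others in the source may bear on it.

In a functional assay on SW-620 cells (Homo sapiens) for inhibition, read by MTT assay, with a stated time of 48 h (a higher number here means a weaker inhibitor, a lower number a stronger inhibitor), compound 1 (`Cc1ccc(NC(=S)NC(=O)c2ccc(OCc3cccc(Cl)c3)cc2)cc1-c1nc2ccccc2[nH]1`) gives > 100000 nM, which is a limit of the assay and not a number. Compound 2 (`Cc1ccc(NC(=S)NC(=O)c2ccc(OCc3ccccc3F)cc2)cc1-c1nc2ccccc2[nH]1`) gives 6440 nM. Placing 2-fluorophenyl where 3-chlorophenyl stood produced an at least 15-fold lower number from compound 1 to compound 2 (1.19 log units; beyond the scatter). Compound 3 (`Cc1ccc(NC(=S)NC(=O)c2ccc(OCc3cccc(F)c3)cc2)cc1-c1nc2ccccc2[nH]1`) instead carries fluoro in place of chloro on an aromatic carbon, meta to a large group (fluoro in place of chloro on an aromatic carbon). This is a single comparison with a different group, yet a lower number is expected in this assay on the strength of an at least 15-fold lower number from compound 1 to compound 2 (1.19 log units; beyond the scatter). The expected change is an at least 6.6-fold lower number from compound 1 to compound 3 (0.82 log units; beyond the scatter). For compound 3, the estimate is 15000 nM, with an expected range of 3000 nM to 80000 nM.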

Compound 3, half-maximal inhibitory concentration: > 100000 nM
Compound 3: a limit, no number; the forecaster's own chance of this, stated with the estimate: 30%; middle value at least 6.6-fold (0.82 log units) from the limit.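

With fluoro kept and only its place on the ring changed, going from 2-fluorophenyl to 3-fluorophenyl gives an at least 15-fold higher number from compound 2 to compound 3 (1.19 log units; beyond the scatter) in this assay. Fluoro alone therefore does not bring a readable number here; among these compounds, only the 2-fluorophenyl of compound 2 does. Compound 3 gives a limit of the assay, not a number, so its step from compound 1 cannot be read: the limit of > 100000 nM in this assay, at which 2 of the 3 values shown sit.

Still open, from the compounds shown here alone, is whether the gain belongs to fluoro or to the ring position. A 2-chlorophenyl or 2-methoxyphenyl group would be needed to separate the two.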